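This account rests on a few compounds, and the source may have more. Where it says the series, first, only, none or still open, it means among the compounds named here.

In an ADME assay on HepG2 cells (Homo sapiens) for cytotoxicity, read by MTT assay, with a stated time of 72 h (on this read-out higher numbers stand for lower toxicity in this test and lower numbers for higher toxicity in this test), compound 1 `O=[N+]([O-])c1c(CSc2ccccc2)nc2c(Sc3ccc(Cl)cc3)cc(Cl)cn12` gives only a limit, > 15600 nM, so no number places it against the other values. Compound 2 `CS(=O)(=O)Cc1nc2c(Br)cc(Cl)cn2c1N` likewise gives only a limit, > 125000 nM. Compound 3 `O=[N+]([O-])c1c(CS(=O)(=O)c2ccccc2)nc2c(Nc3ccccc3)cc(Cl)cn12` also gives only a limit, > 3900 nM. Within the data shown here, since all three values are limits, no step between measured compounds can be sized. Compound 4 `O=[N+]([O-])c1c(CS(=O)(=O)C2CCCCC2)nc2c(Sc3ccc(Cl)cc3)cc(Cl)cn12` differs from compound 1 in this way: cyclohexylsulfonyl in place of phenylsulfanyl on a saturated chain carbon bound to an aromatic carbon. Among the measured compounds shown here, with no measured step to lean on, the change from compound 1 to compound 4 is expected to stay within the scatter in this assay, most likely ending again at a limit. Compound 4 is therefore expected to give about 20000 nM, between 8000 nM and 80000 nM. The step this estimate means is a step that the limit leaves unreadable from compound 1 to compound 4.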

Compound 4, half-maximal cytotoxic concentration: > 31200 nM
Compound 4 gave a limit, no number (the forecaster's own chance of this, stated with the estimate: 70%); at least 1.5-fold (0.19 log units) between middle value and limit.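

Compound 1 and compound 4 both give only limits in this assay, so the step between them cannot be read. The compounds shown leave open whether cyclohexylsulfonyl in place of phenylsulfanyl changes this read-out at all, and by how much.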